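A few compounds are considered here, and "the series" means these few. Any claim that something is new, unique, unknown or untested is made for them only; others in the source may bear on it.

For the measured compounds named here, in an ADME assay on microsomes from liver (Mus musculus) for metabolic stability, read by LC-MS, using NADPH, tested at 4.6 uM (on this read-out higher numbers stand for a longer-lived compound and lower numbers for a shorter-lived compound), compound 1 `O=C(NCCCCc1ccccc1)n1cc(-c2ccccc2)oc1=O` gives 0.667 h, the only true number so far. Compound 2 `CCCCCNC(=O)n1cc(-c2ccccc2)oc1=O` reaches only a limit of the assay, < 0.0834 h.

Going by the values given here, the one measured step, an at least 7.9-fold lower number from compound 1 to compound 2 (0.90 log units; beyond the scatter), is methyl in place of phenyl on a saturated chain carbon. Compound 3 `COc1cccc(-c2cn(C(=O)NCCCCc3ccccc3)c(=O)o2)c1` keeps the chain of compound 1 and differs elsewhere: methoxy in place of hydrogen on an aromatic carbon. This is methoxy in place of hydrogen on an aromatic carbon, phenyl to 3-methoxyphenyl.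

Among the compounds with values here, the step on the chain therefore gives no size to carry over, and no measured step touches this place. No change beyond the usual scatter is expected in this assay, so no direction is predicted with confidence. The expected step is a 1.3-fold lower number from compound 1 to compound 3 (0.13 log units; within the scatter). For compound 3 the estimated half-life is 0.5 h, with an expected range from 0.17 h to 1.2 h.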

Compound 3, half-life: 0.5 h
Beside the measured number, compound 3's estimate shows no gap at the digits printed; the measured number falls inside the stated range.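

Putting methoxy in place of hydrogen on this aromatic carbon gives a 1.3-fold lower number from compound 1 to compound 3 (0.13 log units; within the scatter) in this assay. This is the first place shown on the aromatic ring, and a group of this size can be added there without a shift beyond the scatter, whereas the earlier step on the chain did go beyond it. Compound 2 stands only at a limit of the assay, not at a number, so the step to compound 3 is the first read between two true values: the limit of < 0.0834 h in this assay, at which 1 of the 3 values shown sits.

One group at one carbon says little about others, so an amine or a carboxylic acid at the same place remains an open question. As far as these compounds go, whether methoxy would behave alike on a compound with the shorter pentyl chain of compound 2 also stays open.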